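The source may hold more compounds than are shown below. What is called first, only, known or untested is meant among the compounds shown, and "the series" means these compounds.

Compound 1 `Cc1cc2c(cc1Cc1ccc(C(=O)NC[C@H]3CC[C@H](C(N)=O)CC3)o1)C(C)(C)CCC2(C)C` in an assay on isolated protein for binding affinity to Gonadotropin-releasing hormone receptor (Homo sapiens); on this read-out lower numbers stand for stronger inhibition and higher numbers for weaker inhibition: 13 nM. Compound 2 `Cc1cc2c(cc1Cc1ccc(C(=O)NCc3ccc(CN)cc3)o1)C(C)(C)CCC2(C)C` in this assay: 140 nM.

Compound 2 has the highest of the two numbers; its nearest neighbour is compound 1, with an 11-fold higher number from compound 1 to compound 2 (1.03 log units; beyond the scatter). Compound 3 `Cc1cc2c(cc1Cc1ccc(C(=O)NCC3CCN(C(=N)N)CC3)o1)C(C)(C)CCC2(C)C` differs from compound 2 by a group of 9 heavy atoms (6 carbon, 3 nitrogen; one six-membered non-aromatic ring with 1 hetero atom) in place of a group of 8 heavy atoms (7 carbon, 1 nitrogen; one six-membered aromatic ring of carbon only), on a saturated chain carbon bound to an amide-type nitrogen. Going by the values given here, the only step that bears on this is the one from compound 1 to compound 2, which was large; compound 3 returns to a six-membered non-aromatic ring at the same place, so the number is expected to fall part of the way back, by a 4.0-fold lower number from compound 2 to compound 3 (0.60 log units; beyond the scatter). Compound 3 is therefore estimated at 35 nM, within 8 nM to 140 nM.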

Compound 3, inhibition constant: 220 nM
Estimate against measurement, compound 3: 6.3-fold (0.80 log units) below, and the stated range ends below it.
By their numbers in this assay, from the lowest: compound 1; then compounds 2 and 3 (each within the scatter of the next).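

At this saturated chain carbon bound to an amide-type nitrogen, a six-membered non-aromatic ring alone does not bring back the value of compound 1 in this assay, with a 17-fold higher number from compound 1 to compound 3 (1.23 log units; beyond the scatter) as the step. The aromatic ring of compound 2 and the ring with 1 hetero atom cannot be told apart, since a 1.6-fold higher number from compound 2 to compound 3 (0.20 log units; within the scatter) is the step between them. No measured evidence available here explains either step. Compound 1 and compound 3 differ in both the ring atoms and the group the ring carries, so these two changes remain unseparated. A cyclohexyl ring carrying aminomethyl, or a piperidine ring carrying carbamoyl, would separate them.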